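The source may hold more compounds than are shown below. What is called first, only, known or untested is meant among the compounds shown, and "the series" means these compounds.

Working notes on the series.

Compound 1 `CCCC[C@]1(CC)CS(=O)(=O)c2ccc(OC)cc2[C@@H](c2ccccc2)[C@H]1O` and compound 2 `CCCC[C@]1(CC)CS(=O)(=O)c2ccc(N(C)C)cc2[C@@H](c2ccccc2)[C@H]1O` share one core. In an assay on cells for inhibition of ileal sodium/bile acid cotransporter (Homo sapiens) (a higher number here means a weaker inhibitor, a lower number a stronger inhibitor), compound 1 gives 55 nM and compound 2 gives 5 nM. Compound 2 and compound 1 differ in one place, (methoxy in place of dimethylamino on an aromatic carbon), and this change brings an 11-fold higher number from compound 2 to compound 1 (1.04 log units; beyond the scatter).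

Compound 3 `CCCCC1(CCCC)CS(=O)(=O)c2ccc(N(C)C)cc2[C@@H](c2ccc(F)cc2)[C@H]1O` carries a second core; in this assay compound 3 gives 10 nM. The values of compound 3 and compound 2 lie within the usual scatter of each other. The difference between the core of compound 3 and the core of compound 2 is not broken down here.

Compound 4 `CCCCC1(CCCC)CS(=O)(=O)c2ccc(OC)cc2[C@@H](c2ccc(F)cc2)[C@H]1O` is not yet measured. It differs from compound 3 by methoxy in place of dimethylamino on an aromatic carbon. The place line of this change reads the same, word for word, as that from compound 2 to compound 1, so it is the same change made on the second core.

Among the compounds with values here, the expectation for compound 4 rests on the one measured step of this kind: the step of an 11-fold higher number from compound 2 to compound 1 (1.04 log units; beyond the scatter) is taken as the guide, and from compound 3 to compound 4 a step of about an 11-fold higher number from compound 3 to compound 4 (1.04 log units; beyond the scatter) is expected in this assay. On that basis compound 4 is estimated at 110 nM, with a range from 40 nM to 300 nM.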

Compound 4, half-maximal inhibitory concentration: 50 nM
For compound 4 the middle estimate is 2.2-fold (0.34 log units) above the measured one, and the stated range covers the measured number.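

In this assay, methoxy in place of dimethylamino on an aromatic carbon again gives a weaker inhibitor on the second core, with a 5.0-fold higher number from compound 3 to compound 4 (0.70 log units; beyond the scatter). The change therefore carries over in direction, and the two step sizes cannot be told apart: the same change on two cores in this assay, an 11-fold higher number (1.04 log units; beyond the scatter) from compound 2 to compound 1 and a 5.0-fold higher number (0.70 log units; beyond the scatter) from compound 3 to compound 4, 2.2-fold (0.34 log units) apart, within the scatter of two such steps. This rests on two pairs in one assay, so it supports no rule for cores beyond these two and does not explain why compound 2 and compound 3 give lower numbers than their methoxy partners.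

The compounds shown leave open how other groups on this aromatic carbon would compare, such as a primary amine, a hydroxyl or a longer alkoxy chain like ethoxy. Also open, on these data alone, is whether any single part of the difference between the core of compound 2 and the core of compound 3 affects the step, and whether a third core would give a step of similar size.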